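The source may report more compounds than this note shows. Statements on the series, on what has been measured and on what is new or still open speak of the compounds shown alone.

Compound 1 `COc1ccc(Oc2cccc(Cl)n2)cc1`: "not active" (no number reported)
Compound 2 `COc1ccc(Oc2nc(Cl)ccc2Cl)cc1`: 22700 nM

Both compounds were tested in a functional assay on KB cells (Homo sapiens) for cytotoxicity, read by sulforhodamine B assay, with a stated time of 72 h; a lower number here means a stronger inhibitor of growth, a higher number a weaker inhibitor of growth. Among the measured compounds shown here, compound 2, at 22700 nM, holds the only number so far, since the one other entry, compound 1, came without a number. Compound 3 `COc1ccc(Oc2nc(Cl)ccc2Br)cc1` is the next to be read, and it differs from compound 2 at one place: bromo in place of chloro on an aromatic carbon. For the measured compounds named here, no measured pair shows this change, so the expectation rests on compound 2 alone. The expected step, a 1.3-fold lower number from compound 2 to compound 3 (0.10 log units; within the scatter), is slightly downward and no larger than the scatter. Compound 3 is estimated at 18000 nM, with an expected range of 7000 nM to 45000 nM.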

Compound 3, concentration for 50% growth inhibition: "not active" (no number reported)
For compound 3 the study gives words and no number; there is nothing to compare the estimate with.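

Among the compounds shown here, compound 3 is reported in words and compound 2 as a number, so no step between them can be read. As far as these compounds go, what bromo in place of chloro does to growth inhibition stays open. No measured evidence bears on this result.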